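The compounds below may be only part of what the source reports. "The series", "measured", "known", "first", "only" and "open" are said of these compounds alone.

Of the compounds shown here, two of a shared core have been measured in a functional assay on KB cells (Homo sapiens) for cytotoxicity, read by MTT assay, with a stated time of 72 h; on this read-out higher numbers stand for weaker inhibition and lower numbers for stronger inhibition. Compound 1 is `COc1ccc2c(c1)[n+]([O-])nc(NCOC(C)c1ccccc1)[n+]2[O-]`, and in this assay compound 1 gives 12400 nM. Compound 2 is `COCNc1n[n+]([O-])c2ccccc2[n+]1[O-]`, a smaller molecule built on the same core, and in this assay compound 2 gives 9070 nM. Going by the values given here, these two numbers sit within the usual scatter of each other, so neither compound is set apart from the other on the evidence so far, and no step between a matched pair of measured compounds is available to guide what a single change does.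

Compound 3 is `[O-][n+]1nc(NCOCc2ccc(Cl)cc2)[n+]([O-])c2ccccc21`. It differs from compound 2 in one place: 4-chlorophenyl in place of hydrogen on a saturated chain carbon bound to an oxygen on a saturated carbon. Because compound 1, which carries a larger side chain with an aromatic ring, gives 12400 nM, close to compound 2, adding an aromatic ring in this region is not expected to move the number far. The step of a 1.1-fold lower number from compound 2 to compound 3 (0.05 log units; within the scatter) is therefore expected to stay within the scatter. Compound 3 is expected to give about 8000 nM in this assay, with a range from 3000 nM to 20000 nM.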

Compound 3, half-maximal inhibitory concentration: 8260 nM
Estimate against measurement, compound 3: 1.0-fold (0.01 log units) below, and the stated range covers the measured number.
By their numbers in this assay, from the lowest: compounds 3, 2 and 1 (each within the scatter of the next).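

In this assay, bringing in 4-chlorophenyl where a hydrogen stood gives the step of a 1.1-fold lower number from compound 2 to compound 3 (0.04 log units; within the scatter) and so leaves the number within the usual scatter. Going by these compounds alone, this is the first change in a single place in this set, and it shows that this position can take 7 additional heavy atoms, including a six-membered aromatic ring of carbon only and a chlorine, without a clear shift in the read-out. No supporting measurement bears on this result, so the reason for it remains unknown.

A step this small cannot tell whether the ring and the chlorine each have little effect or whether their effects cancel, and a plain phenyl group at the same place would help to separate the two. Going by these compounds, it also remains open whether this position matters at all, which a quite different group there, such as an amine, a carboxylic acid or a longer chain, could test if it gave a step beyond the scatter.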